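Lengthening a selenocyanate chain and swapping ester for ether

A few compounds are considered here, and "the series" means these few. Any claim that something is new, unique, unknown or untested is made for them only; others in the source may bear on it.

Measured compounds:
compound 1, `COc1ccc(N(C)c2nc(C)nc3ccccc23)cc1C(=O)OCCC[Se]C#N`, 340 nM;
compound 2, `COc1ccc(N(C)c2nc(C)nc3ccccc23)cc1C(=O)OCCCCC[Se]C#N`, 667 nM;
compound 3, `C[Se]c1ccc(N(C)c2nc(C)nc3ccccc23)cc1C`, 6 nM.

In a functional assay on HepG2 cells (Homo sapiens) for inhibition, read by MTT assay, with a stated time of 48 h (a lower number here means a stronger inhibitor, a higher number a weaker inhibitor), compound 1 stands second highest of the three numbers. Its nearest neighbour is compound 2, whose value sits within the usual scatter of it, so the two cannot be ranked. Compound 3 gives the lowest number, far below compound 1 and beyond the scatter.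

Compound 4, `COc1ccc(N(C)c2nc(C)nc3ccccc23)cc1OCCCCCC[Se]C#N`, is not yet measured. It differs from compound 1 in one place: a group of 10 heavy atoms (7 carbon, 1 nitrogen, 1 oxygen, 1 selenium; no ring) in place of a group of 9 heavy atoms (5 carbon, 1 nitrogen, 2 oxygen, 1 selenium; no ring), on an aromatic carbon. The new group sits on an aromatic carbon of a six-membered aromatic ring of carbon only, ortho to a methoxy group and meta to a large group.

For the measured compounds named here, the only measured step that bears on this change is the chain lengthening a 2.0-fold higher number from compound 1 to compound 2 (0.29 log units; within the scatter), which stayed within the scatter. Going by the values given here, no measured pair shows what replacing the ester linkage by an ether linkage does, so that part of the change is uncharted.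

The expectation is therefore a step of about a 1.5-fold higher number from compound 1 to compound 4 (0.17 log units; within the scatter), likely within the scatter. Compound 4 is estimated at 500 nM, with a range from 150 nM to 1700 nM.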

Compound 4, half-maximal inhibitory concentration: 4890 nM
The estimate for compound 4 lay 9.8-fold (0.99 log units) below the measured number; measured number above the stated range.
By their numbers in this assay, from the lowest: compound 3; then compounds 1 and 2 (each within the scatter of the next); then compound 4.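

In this assay, replacing the ester-linked chain on this aromatic carbon with a longer ether-linked chain gives a 14-fold higher number from compound 1 to compound 4 (1.16 log units; beyond the scatter), a large step. Lengthening the chain while keeping the ester gave only a 2.0-fold higher number from compound 1 to compound 2 (0.29 log units; within the scatter), which lies within the scatter, so the ester-to-ether change at this position has a much clearer effect on the number than that lengthening alone. No measurement shown here accounts for the large rise.

The linkage and the chain length change together in this step, leaving open how much of the rise belongs to each. Also open, from the compounds shown here alone, is whether an ether linkage with a shorter chain, or an amide linkage, would bring the number closer to that of compound 1.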